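Swapping an amino for a methoxy on the ether side chain

The source may hold more compounds than are shown below. What is called first, only, known or untested is meant among the compounds shown, and "the series" means these compounds.

Compound 1 `CN(C)Cc1cc(F)ccc1-c1nc(-c2ccc3[nH]c(=O)oc3c2)cs1`: in an assay on isolated protein for inhibition of protein phosphatase 1D (Homo sapiens), read by malachite green (on this read-out higher numbers stand for weaker inhibition and lower numbers for stronger inhibition), compound 1 gives < 20000 nM, which is a limit of the assay rather than a number.
Compound 2 `NCCOCc1cc(F)ccc1-c1nc(-c2ccc3[nH]c(=O)oc3c2)cs1`: in this assay compound 2 gives < 20000 nM, again only a limit.

The two measured compounds share one core and differ only in the group hanging from the saturated chain carbon bound to the aromatic ring. The step that the two limits leave unreadable from compound 1 to compound 2 therefore cannot be sized, since both values sit at the limit of < 20000 nM in this assay, at which 2 of the 2 values shown sit. Compound 2 thus stands at the limit, with nothing to rank it against.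

Compound 3 `COCCOCc1cc(F)ccc1-c1nc(-c2ccc3[nH]c(=O)oc3c2)cs1` has not been measured. It differs from compound 2 by methoxy in place of amino on a saturated chain carbon, two bonds along the chain from an oxygen on a saturated carbon. Going by the values given here, the only measured step touches the same side chain but is unreadable, so it gives no direction for this change, and no pattern can be claimed from two limits.

The step from compound 2 to compound 3 is therefore expected to be a step that the limit leaves unreadable from compound 2 to compound 3, within the scatter. Compound 3 is estimated at 8000 nM in this assay, with a range from 1500 nM to 20000 nM, and most likely only a limit will again be reported.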

Compound 3, half-maximal inhibitory concentration: < 20000 nM
Compound 3: no number, only a limit; the forecaster's own chance of this, stated with the estimate: 60%; the middle value lies beyond the limit too.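

In this assay compound 3 gives < 20000 nM, which is a limit of the assay and not a number. No step among compound 1, compound 2 and compound 3 can be read, since all their values sit at the same limit: the limit of < 20000 nM in this assay, at which 3 of the 3 values shown sit.

The compounds shown leave open whether changing this side chain alters inhibition at all, and in which direction.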